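Series notes: methyl in place of hydrogen, second instance

The source may hold more compounds than are shown below. What is called first, only, known or untested is meant among the compounds shown, and "the series" means these compounds.

Measured compounds:
compound 1 `COc1ccc(-c2cn(CC(=O)Nc3nccs3)nn2)cc1` — 510 nM
compound 2 `O=C(Cn1cc(-c2ccccc2Cl)nn1)Nc1nccs1` — 60 nM
compound 3 `COc1ccc(-c2cn(CC(=O)Nc3nc(C)cs3)nn2)cc1` — 3890 nM

In a functional assay on BMDM cells (Mus musculus, strain C57BL/6) for inhibition, with a stated time of 2 days (a lower number here means a stronger inhibitor, a higher number a weaker inhibitor), compound 2 gives the lowest number of the three, and its step to compound 1 and to compound 3 is each beyond the scatter. The difference between the core of compound 1 and the core of compound 2 is not broken down here.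

One structural change occurs twice in the set. From compound 1 to compound 3 the change is methyl in place of hydrogen on an aromatic carbon, and it gave a 7.6-fold higher number from compound 1 to compound 3 (0.88 log units; beyond the scatter). Compound 4 `Cc1csc(NC(=O)Cn2cc(-c3ccccc3Cl)nn2)n1` is not yet measured; it differs from compound 2 by methyl in place of hydrogen on an aromatic carbon. The place lines for the two changes read the same word for word, so this is the same change made on a different core.

Expectation for compound 4 in this assay: because compound 1 to compound 3 gave a 7.6-fold higher number from compound 1 to compound 3 (0.88 log units; beyond the scatter), the same change is expected to raise the number for compound 4 as well, though with only one prior instance the size is uncertain. The expected step is a 6.7-fold higher number from compound 2 to compound 4 (0.82 log units; beyond the scatter). Compound 4 is expected to give 400 nM, with a range of 120 nM to 1500 nM. Going by the values given here, this rests on the single step from compound 1 to compound 3 and on the value of compound 2, 60 nM.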

Compound 4, half-maximal inhibitory concentration: 1240 nM
Compound 4: middle estimate off by 3.1-fold (0.49 log units), on the low side, within the range that was stated.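

In this assay, methyl in place of hydrogen on an aromatic carbon of the 1,3-thiazol-2-yl group moved the number in the same direction on both cores, with a 7.6-fold higher number from compound 1 to compound 3 (0.88 log units; beyond the scatter) and now a 21-fold higher number from compound 2 to compound 4 (1.32 log units; beyond the scatter), so the loss seen on the core of compound 1 recurs on the core of compound 2. The direction of the change carried from one core to the other, but its size did not, and the gap between the two steps is larger than repeat measurements would explain: the same change on two cores in this assay, a 7.6-fold higher number (0.88 log units; beyond the scatter) from compound 1 to compound 3 and a 21-fold higher number (1.32 log units; beyond the scatter) from compound 2 to compound 4, 2.7-fold (0.43 log units) apart, beyond the scatter of two such steps. These two pairs show that the size of this step depends on the core in this series, but they do not show which feature of the core sets that size, and two pairs give no general rule for further cores.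

On these data alone, it remains open whether a larger or differently built group on the same aromatic carbon, such as ethyl, hydroxymethyl or an aminomethyl group, would follow the same direction in this assay. As far as these compounds go, it also remains open how the step would behave on a core carrying another group on the phenyl ring, such as a nitrile or a carboxylic acid.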